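The source may hold more compounds than are shown below. What is called first, only, known or untested is meant among the compounds shown, and "the series" means these compounds.

Compound 1 `CC1(C)C2CCC1(C)C(OC(=O)/C=C/c1ccc(O)c(O)c1[N+](=O)[O-])C2`: 51800 nM
Compound 2 `CC1(C)C2CCC1(C)C(OC(=O)/C=C/c1cc(O)c(O)c(Br)c1)C2`: 29000 nM
Compound 3 `O=C(/C=C/c1cc(O)c(O)c(Cl)c1)OCCc1ccccc1`: "not determined" (no result reported)

These results come from a functional assay on SiHa cells (Homo sapiens) for inhibition, read by MTT assay; a lower number here means a stronger inhibitor, a higher number a weaker inhibitor. Compound 2, at 29000 nM, lies within the usual scatter of compound 1, at 51800 nM, so the two cannot be ranked. Compound 4 `CC1(C)C2CCC1(C)C(OC(=O)/C=C/c1cc(O)c(O)c(Cl)c1)C2` keeps the rest of compound 2 and makes one change: chloro in place of bromo on an aromatic carbon. Going by the values given here, no measured pair shows this swap, and compound 3, which also carries chloro, has no number to offer. With only compound 2 at 29000 nM as a guide, no shift beyond the scatter is expected in this assay. The expected step is a 1.1-fold higher number from compound 2 to compound 4 (0.04 log units; within the scatter). For compound 4 the estimated value is 32000 nM, with an expected range of 16000 nM to 62000 nM.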

Compound 4, half-maximal inhibitory concentration: 33800 nM
Compound 4: the middle estimate sits 1.1-fold (0.02 log units) below what was measured; the measured number falls inside the stated range.
By their numbers in this assay, from the lowest: compounds 2, 4 and 1 (each within the scatter of the next).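

In this assay, chloro in place of bromo on this aromatic carbon, ortho to a hydroxy group, gives a 1.2-fold higher number from compound 2 to compound 4 (0.07 log units; within the scatter). Going by these compounds alone, this is the first measured pair for this swap, and it shows that compound 2 and compound 4 cannot be told apart, so this assay does not distinguish between these two halogens at this position. Nothing measured here offers an explanation for this result. From the compounds shown here alone, whether a methoxy group, an amine or a carboxylic acid on this carbon would stand apart from the two halogens remains open.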